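Series notes: fluoro to dimethylamino, ahead of compound 3

The source may hold more compounds than are shown below. What is called first, only, known or untested is meant among the compounds shown, and "the series" means these compounds.

compound 1 `O=C(N/N=C/c1cccc(F)c1)c1cnccn1` — 40%
compound 2 `O=C(N/N=C/c1ccc(F)cc1)c1cnccn1` — 71%

In an ADME assay on J774 cells (Mus musculus) for cytotoxicity, read by MTT assay, with a stated time of 48 h, tested at 150 ug/mL (on this read-out higher numbers stand for a weaker effect at the one concentration tested and lower numbers for a stronger effect), compound 2 gives 71%, the highest of the two numbers; the nearest is compound 1 with 40%, a gap beyond the scatter. Compound 3 `CN(C)c1ccc(/C=N/NC(=O)c2cnccn2)cc1` differs from compound 2 by dimethylamino in place of fluoro on an aromatic carbon. Going by the values given here, no pair of measured compounds carries this change, so nothing here shows how large a step it brings. The step of a number 6 percentage points lower from compound 2 to compound 3 (within the scatter) is expected to be small, within or just beyond the scatter, in either direction. Compound 3 is therefore estimated at 65%, with a range from 40% to 90%.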

Compound 3, a percentage reported as activity, at one concentration (the size of the read-out at that concentration, not a potency): 89%
Beside the measured number, compound 3's estimate is 24 percentage points below it; low and high end bracket the measured number.
By their numbers in this assay, from the lowest: compound 1; then compound 2; then compound 3.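

In this assay, dimethylamino in place of fluoro on an aromatic carbon para to a large group brings a number 18 percentage points higher from compound 2 to compound 3 (beyond the scatter), the first measured size for this change. On this read-out, the step means a weaker effect at the one concentration tested, so the group at this position does alter the result. Nothing measured here bears on what lies behind the step.

This single pair leaves open whether a primary amine or a carboxylic acid at the same position would give a similar step. It also leaves open whether a longer chain on the nitrogen would extend it.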